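Two Fluorines Change Places on the Benzyl Ring

The compounds below may be only part of what the source reports. "The series", "measured", "known", "first", "only" and "open" are said of these compounds alone.

Measured compounds:
Compound 1, `CCOC(=O)c1cc(-c2cccc(OCc3cccc(Br)c3)c2)on1`: in an ADME assay on Vero cells (Chlorocebus sabaeus) for cytotoxicity, with a stated time of 72 h (on this read-out higher numbers stand for weaker inhibition and lower numbers for stronger inhibition), compound 1 gives > 128000 nM, a limit of the assay rather than a number.
Compound 2, `CCOC(=O)c1cc(-c2cccc(OCc3ccc(F)cc3)c2)on1`: in this assay compound 2 gives "not determined" (no result reported).
Compound 3, `CCOC(=O)c1cc(-c2cccc(OCc3cc(F)cc(F)c3)c2)on1`: in this assay compound 3 gives > 128000 nM, again a limit of the assay.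

Compound 3 therefore stands at the top end of what this assay can report, with no single number attached to it. Compound 1 sits at that same limit, and compound 2 has no result at all, so nothing here separates one compound from another. Among the compounds with values here, the only one-change step among the measured compounds, a step that the two limits leave unreadable from compound 1 to compound 3, cannot be read, since both of its ends are limits; the wider picture is the limit of > 128000 nM in this assay, at which 2 of the 3 values shown sit.

Compound 4, `CCOC(=O)c1cc(-c2cccc(OCc3c(F)cccc3F)c2)on1`, arises from compound 3 by 2,6-difluorophenyl in place of 3,5-difluorophenyl on a saturated chain carbon bound to an oxygen on an aromatic ring. Within the data shown here, the single step that bears on this change tells nothing about its size or direction, so no movement beyond the scatter is expected, and the step of a number no higher from compound 3 to compound 4 (the limit leaves the size open) is estimated to be flat. Compound 4 is expected to give about 128000 nM, most likely reported as a limit again, within a range of 64000 nM to 256000 nM.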

Compound 4, half-maximal inhibitory concentration: > 128000 nM
Compound 4: only a limit was reported; the forecaster's own chance of this, stated with the estimate: 85%; the middle value lies on the limit itself.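

Neither step to compound 4, from compound 3 or from compound 1, can be read, since all three compounds rest at the same assay limit: the limit of > 128000 nM in this assay, at which 3 of the 4 values shown sit.

The compounds shown leave open what single number each would give, and whether swapping these ring groups changes the read-out at all.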